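A few compounds are considered here, and "the series" means these few. Any claim that something is new, unique, unknown or untested is made for them only; others in the source may bear on it.

Compound 1 `COc1ccc(N(C)C(=O)N(C)c2cc(OC)c(OC)c(OC)c2)cc1` is a urea in which both nitrogens carry a methyl group, one nitrogen bearing a trimethoxyphenyl ring and the other a 4-methoxyphenyl ring. In a functional assay on Daoy cells (Homo sapiens) for cytotoxicity, read by MTT assay, with a stated time of 72 h (on this read-out higher numbers stand for weaker inhibition and lower numbers for stronger inhibition), compound 1 gives >= 125000 nM, which is a limit of the assay rather than a measured number. Compound 2 `COc1cc(N(C)C(=O)c2cccc([N+](=O)[O-])c2)cc(OC)c1OC` keeps the trimethoxyphenyl half but joins it through an amide to a nitrophenyl ring. In this assay compound 2 gives >= 125000 nM, again a limit. Compound 1 therefore stands nowhere distinct among the numbers shown: both values sit at the limit of >= 125000 nM in this assay, at which 2 of the 2 values shown sit, so no ordering between the two compounds can be read, and no measured step exists to show how any change moves the read-out.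

Compound 3 `COc1cc(N(C)C(=O)N(C)c2ccc(F)cc2)cc(OC)c1OC` differs from compound 1 in one place only, (fluoro in place of methoxy on an aromatic carbon). Within the data shown here, no measured step is available to say what this exchange does. In this assay the expected step is a step that the limit leaves unreadable from compound 1 to compound 3, that is, no move beyond the usual scatter. Compound 3 is accordingly estimated at 150000 nM, with a range from 40000 nM to 500000 nM, and most likely the result would again be reported only as a limit.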

Compound 3, half-maximal inhibitory concentration: >= 125000 nM
Compound 3: only a limit was reported (the forecaster's own chance of this, stated with the estimate: 80%); the middle value lies beyond the limit too.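

In this assay compound 1 and compound 3 are both reported only as limits, so no step can be read for fluoro in place of methoxy on an aromatic carbon. The compounds shown leave open how far this exchange moves the read-out, and whether any change to the shared core gives a measurable value at all.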